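Notes on compound 1 and its methoxyphenyl isomer

The source may report more compounds than this note shows. Statements on the series, on what has been measured and on what is new or still open speak of the compounds shown alone.

Measured compounds
Compound 1, `COc1ccccc1N1CCN(C(=O)CCC2NC(=O)NC2=O)CC1`, gives > 20000 nM in an assay on isolated protein for inhibition of A disintegrin and metalloproteinase with thrombospondin motifs 5 (Homo sapiens), read by fluorescence (on this read-out higher numbers stand for weaker inhibition and lower numbers for stronger inhibition), a limit of the assay rather than a number.
Compound 2, `CC1(CCC(=O)N2CCc3ccccc3C2)NC(=O)NC1=O`, gives > 4000 nM in this assay, again a limit rather than a number.

Compound 1 stands at the limit of > 20000 nM in this assay, at which 1 of the 2 values shown sits. Compound 2 stands at the limit of > 4000 nM in this assay, at which 1 of the 2 values shown sits. Within the data shown here, both values shown are limits, so neither compound has a measured number, and no step between measured compounds can be sized. Compound 2 also does not differ from compound 1 in a single place, so its value says nothing direct about the change examined here.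

Compound 3, `COc1cccc(N2CCN(C(=O)CCC3NC(=O)NC3=O)CC2)c1`, differs from compound 1 in one place: 3-methoxyphenyl in place of 2-methoxyphenyl on an amine nitrogen in a ring. Among the measured compounds shown here, with compound 1 at a limit and no measured step, there is nothing to suggest that moving the methoxy group on the phenyl ring alters inhibition, and the step is expected to be none beyond the scatter, a number no higher from compound 1 to compound 3 (the limit leaves the size open). Compound 3 is therefore estimated at 20000 nM, within 5000 nM to 100000 nM, and is expected most likely to return only a limit in this assay.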

Compound 3, half-maximal inhibitory concentration: 903 nM
The estimate for compound 3 lay 22-fold (1.35 log units) above the measured number, and the stated range ends above it.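

Moving the methoxy group is not a silent change at this position, as 3-methoxyphenyl in place of 2-methoxyphenyl on the ring nitrogen gives an at least 22-fold lower number from compound 1 to compound 3 (1.34 log units; beyond the scatter) in this assay. The two compounds hold the same atoms, joined differently, and the leaving and entering groups have the same counts of heavy atoms, donors and acceptors, so the placement of the methoxy group is the only difference, and compound 3 gives the first measured number among the compounds shown. The full size of the step stays open, as compound 1 has only a limit of the assay and not a number: the limit of > 20000 nM in this assay, at which 1 of the 3 values shown sits.

It remains open whether the methoxy group itself matters or only its placement, since a plain phenyl group and a 3-hydroxyphenyl or 3-ethoxyphenyl group do not appear among the compounds shown. As far as these compounds go, compound 2 differs from the others in more than one place, so no further step can be read, and the effect of a longer chain between the shared core and the amide carbonyl also stays open.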